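Methoxy for Methyl: One Change Tried on a Second Core

A few compounds are considered here, and "the series" means these few. Any claim that something is new, unique, unknown or untested is made for them only; others in the source may bear on it.

The study compares three measured compounds and one that awaits measurement, all judged in a functional assay on HepG2 cells (Homo sapiens) for antiproliferative activity, read by MTT assay; on this read-out higher numbers stand for weaker inhibition and lower numbers for stronger inhibition. Compound 1 `COc1ccc(-c2ccnc(Nc3ccc(Cl)cc3Cl)n2)cc1` gives 190 nM in this assay, whereas compound 2 `Cc1ccc(-c2ccnc(Nc3ccc(Cl)cc3Cl)n2)cc1` gives 344000 nM. These two differ in a single place, (methoxy in place of methyl on an aromatic carbon), and that change made the step of a 1800-fold lower number from compound 2 to compound 1 (3.26 log units; beyond the scatter). Compound 3 `Cc1cccc(Nc2nccc(-c3ccc(Cl)cc3Cl)n2)c1` is built from the same atoms as compound 2, joined differently; the difference between the two cores is not broken down here. In this assay compound 3 gives 13200 nM, a number lying between those of compound 1 and compound 2.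

Compound 4 `COc1cccc(Nc2nccc(-c3ccc(Cl)cc3Cl)n2)c1` has not yet been measured. It differs from compound 3 by methoxy in place of methyl on an aromatic carbon. Within the data shown here, this is the same kind of change as the one from compound 2 to compound 1, but not the same: in the measured pair the group sits para to a large group, whereas in compound 3 and compound 4 it sits meta to a large group, and the two pairs rest on different cores. Among the measured compounds shown here, only one measured example of the change exists, so its size is a loose guide. A lower number is expected for compound 4 than for compound 3, with an expected step of an 8.8-fold lower number from compound 3 to compound 4 (0.94 log units; beyond the scatter), kept smaller than the earlier one because the step of a 1800-fold lower number from compound 2 to compound 1 (3.26 log units; beyond the scatter) comes from a single pair on another core. Compound 4 is therefore expected to give 1500 nM in this assay, most likely between 100 nM and 13000 nM.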

Compound 4, half-maximal inhibitory concentration: 96900 nM
The estimate for compound 4 lay 65-fold (1.81 log units) below the measured number, and the stated range ends below it.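

In this assay, methoxy in place of methyl on an aromatic carbon did not repeat its earlier result on the second core, where the change gave a 7.3-fold higher number from compound 3 to compound 4 (0.87 log units; beyond the scatter), so the number rose where on the first core it had fallen. Set side by side, the two steps run in opposite directions and lie apart by more than the scatter, which shows that in this series the direction and size of the change did not carry from one core to the other: the same change on two cores in this assay, a 1800-fold lower number (3.26 log units; beyond the scatter) from compound 2 to compound 1 and a 7.3-fold higher number (0.87 log units; beyond the scatter) from compound 3 to compound 4, 13000-fold (4.12 log units) apart, beyond the scatter of two such steps This does not show what sets the two results apart, since the pairs differ both in the core and in the place of the group, which in compound 4 sits meta to a large group, and with a single pair on each core these two differences cannot be separated.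

The compounds shown leave open whether the same methoxy would behave alike on one core if only its place on the ring were altered. They also leave open how a hydroxyl, an ethoxy or an amine in that place would compare with methyl and methoxy on either core.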